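A few compounds are considered here, and "the series" means these few. Any claim that something is new, unique, unknown or untested is made for them only; others in the source may bear on it.

Compound 1 `COc1ccc(/C=C/c2cc(OC)cc(OC)c2/C=C/C(=O)c2cc3ccc(Cl)cc3oc2=O)cc1` was tested in an assay on isolated protein for inhibition of Amine oxidase [flavin-containing] B (Homo sapiens), read by fluorescence, with a stated time of 15 min (a lower number here means a stronger inhibitor, a higher number a weaker inhibitor), where compound 1 gives 7360 nM. Within the data shown here, its only measured companion is compound 2 `COc1ccc(/C=C/c2cc(OC)cc(OC)c2/C=C/C(=O)c2cc3cc(F)ccc3oc2=O)cc1`, which in this assay gives 10200 nM. The step of a 1.4-fold higher number from compound 1 to compound 2 (0.14 log units; within the scatter) is small, so these two compounds cannot be told apart on the numbers shown, and compound 1 simply has the smaller of two figures that lie within the usual spread of each other.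

The next compound, compound 3 `COc1ccc(/C=C/c2cc(OC)cc(OC)c2/C=C/C(=O)c2cc3ccc(OC)cc3oc2=O)cc1`, differs from compound 1 by methoxy in place of chloro on an aromatic carbon. Among the measured compounds shown here, no measured step exchanges chloro for methoxy; the one step available, from compound 1 to compound 2, replaces one halogen-bearing ring for another and stays within the scatter, which suggests that a single small change on this ring leaves the number roughly where it is. Compound 3 is therefore expected to give about 8000 nM in this assay, between 3000 nM and 22000 nM, an estimated step of a 1.1-fold higher number from compound 1 to compound 3 (0.04 log units; within the scatter).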

Compound 3, half-maximal inhibitory concentration: 4200 nM
Beside the measured number, compound 3's estimate is 1.9-fold (0.28 log units) above it; the range from low to high includes it.
By their numbers in this assay, from the lowest: compounds 3, 1 and 2 (each within the scatter of the next, the first and the last beyond it).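

Replacing chloro with methoxy on this aromatic carbon gives a 1.8-fold lower number from compound 1 to compound 3 (0.24 log units; within the scatter) in this assay, so compound 1 and compound 3 cannot be told apart on these numbers. Among these compounds, the earlier pair showed only that one halogen-bearing ring could replace another within the scatter. This step extends that picture to a non-halogen group: methoxy has more heavy atoms than chloro and brings a hydrogen-bond acceptor, yet the figure stays within the usual spread.

Still open, as far as these compounds go, is whether an amine, a carboxylic acid or a longer chain such as butoxy on this same carbon would also leave the number within the scatter of compound 1. The compounds shown come with no separate measurement that could explain why chloro and methoxy give such similar figures.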